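Lengthening a Chain: What to Expect for Compound 4

The source may report more compounds than this note shows. Statements on the series, on what has been measured and on what is new or still open speak of the compounds shown alone.

Compound 1, `CNC(=O)c1ccc(S(N)(=O)=O)cc1`, in a physicochemical assay for lipophilicity (on this read-out higher numbers stand for higher lipophilicity and lower numbers for lower lipophilicity), gives -0.31.
Compound 2, `CCNC(=O)c1ccc(S(N)(=O)=O)cc1`, gives 0.03.
Compound 3, `CCCCOC(=O)c1ccccc1S(N)(=O)=O`, gives 2.01.

Compound 1 and compound 2 share one core and differ in a single place: methyl in place of hydrogen on a saturated chain carbon bound to an amide-type nitrogen. That change produced a step of a number 0.34 log units higher from compound 1 to compound 2 (beyond the scatter). Compound 3 is built on another core, and its value is the highest of the three; compound 2 is the nearest to it and compound 1 the furthest, both gaps lying beyond the scatter. The difference between the core of compound 1 and the core of compound 3 is not broken down here.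

Compound 4, `CCCCCOC(=O)c1ccccc1S(N)(=O)=O`, has not yet been measured in this assay. It differs from compound 3 in one place: methyl in place of hydrogen on a saturated chain carbon, four bonds along the chain from an oxygen next to a carbonyl group. Among the compounds with values here, this is the same kind of change as the one from compound 1 to compound 2, a methyl entering in place of a hydrogen on a saturated chain carbon, but the surroundings differ: in the earlier pair that carbon is bound to an amide-type nitrogen, whereas here it sits four bonds along the chain from an oxygen next to a carbonyl group.

The step from compound 3 to compound 4 is expected to be a number 0.45 log units higher from compound 3 to compound 4 (beyond the scatter), a little larger than the earlier one, because the measured change from compound 1 to compound 2 already gave a number 0.34 log units higher from compound 1 to compound 2 (beyond the scatter) and the new methyl sits further out along a chain. Compound 4 is therefore estimated at 2.46 in this assay, expected to fall between 2.1 and 2.8.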

Compound 4, partition coefficient: 2.55
Beside the measured number, compound 4's estimate is 0.09 log units below it, and the stated range covers the measured number.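

In this assay, putting a methyl in place of a hydrogen on a saturated chain carbon gave a number 0.54 log units higher from compound 3 to compound 4 (beyond the scatter) on the core of compound 3, while the earlier pair gave a number 0.34 log units higher from compound 1 to compound 2 (beyond the scatter) on the core of compound 1, so the change moved the reading in the same direction on both cores and both steps count as modest. Within the data shown here, this is only one pair on each core, and the carbon that changes has different surroundings in each: bound to an amide-type nitrogen in one pair, four bonds along the chain from an oxygen next to a carbonyl group in the other, so two pairs cannot establish a general rule or show that the step keeps a fixed size on any further core. No measurement shown here explains either step or says why they have the sizes they do.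

The compounds shown leave open whether a still longer chain on either core would keep raising the reading by a similar amount, or whether the steps would shrink or grow as the chain extends. They also leave open what an amine or a carboxylic acid at the end of such a chain would do to the reading in this assay on either core.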